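Trading the Benzoyloxy Ester for a Propyl Chain

This account rests on a few compounds, and the source may have more. Where it says the series, first, only, none or still open, it means among the compounds named here.

Compound 1 `CC(C)CCN(C)Cc1cn(CC(O)COC(=O)c2ccccc2)nn1`: 0%
Compound 2 `CN(CCCc1ccccc1)Cc1cn(CC(O)COC(=O)c2ccccc2)nn1`: 12%

In an assay on nucleic acid for inhibition of Nucleic Acid, read by fluorescence, tested at 100 uM (on this read-out higher numbers stand for more inhibition at the one concentration tested (going by the name of the read-out) and lower numbers for less inhibition), compound 1 gives 0%, while compound 2 gives 12%. Going by the values given here, compound 2 thus stands highest of the two numbers, and the single measured step, a number 12 percentage points higher from compound 1 to compound 2 (beyond the scatter), concerns the substituent on the amine side of the shared core. Compound 3 `CCCCC(O)Cn1cc(CN(C)CCCc2ccccc2)nn1` differs from compound 2 on the other side of the core: propyl in place of benzoyloxy on a saturated chain carbon, two bonds along the chain from an oxygen on a saturated carbon. Among the compounds with values here, no measured step touches this position, so the data give no guidance on direction; the only step available, from compound 1 to compound 2, is modest and is not comparable. The expectation for this assay is therefore a step of no size beyond the scatter, with a slight lean downward. Compound 3 is estimated at 8%, within 0% to 20%. This estimate corresponds to an expected step of a number 4 percentage points lower from compound 2 to compound 3 (within the scatter).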

Compound 3, a percentage reported as inhibition, at one concentration (the size of the read-out at that concentration, not a potency): 37%
For compound 3 the middle estimate is 29 percentage points below the measured one, and the stated range ends below it.
By their numbers in this assay, from the lowest: compound 1; then compound 2; then compound 3.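

In this assay, going by these compounds alone, the side of the shared core that had stayed unchanged in the earlier compounds proves able to move the read-out: propyl in place of benzoyloxy gives a number 25 percentage points higher from compound 2 to compound 3 (beyond the scatter). The benzoyloxy group is therefore not required for inhibition in this series, as the group that enters has no ring and no hydrogen-bond acceptors and compound 3 still gives the highest number of the three. Nothing at hand gives a reason for this step.

The compounds shown leave open whether a longer chain, such as hexyl, or an amine or a carboxylic acid in the same place would raise or lower the number. From the compounds shown here alone, it also remains open whether the same change would give a step of similar size with the amine side of compound 1.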